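Carboxy in Place of Iodo: Expected Cytotoxicity of Compound 4

The source may hold more compounds than are shown below. What is called first, only, known or untested is meant among the compounds shown, and "the series" means these compounds.

Measured compounds in a toxicity assay on WI-38 cells (Homo sapiens) for cytotoxicity, read by MTT assay, with a stated time of 48 h; a higher number here means a weaker inhibitor, a lower number a stronger inhibitor:
Compound 1 `O=C(/C=C/c1ccc2c(c1)B(O)OC2)c1cccs1` gives 26000 nM.
Compound 2 `O=C(/C=C/c1ccc2c(c1)B(O)OC2)c1ccc(I)cc1` gives only a limit of the assay, > 100000 nM.
Compound 3 `O=C(/C=C/c1ccc2c(c1)B(O)OC2)c1ccccc1F` gives 23600 nM.

Compound 2 therefore stands at the weak end of the three, with no number of its own but only the limit (the limit of > 100000 nM in this assay, at which 1 of the 3 values shown sits). The two steps that reach it are an at least 3.8-fold higher number from compound 1 to compound 2 (0.58 log units; beyond the scatter) and, read the other way, an at least 4.2-fold lower number from compound 2 to compound 3 (0.62 log units; beyond the scatter); both swap the whole ring on the carbonyl carbon rather than a single substituent.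

Compound 4 `O=C(O)c1ccc(C(=O)/C=C/c2ccc3c(c2)B(O)OC3)cc1` differs from compound 2 by carboxy in place of iodo on an aromatic carbon. Among the compounds with values here, no measured step exchanges one substituent for another on the same ring, so none bears directly on this change; the measured steps show only that compound 2 sits at the limit while compound 1 and compound 3 give numbers.

With compound 2 already at the limit, compound 4 is expected to stay weak, with the real chance that this assay again reports only a limit. The estimate for compound 4 is 80000 nM, within 30000 nM to 200000 nM. That estimate means an at least 1.2-fold lower number from compound 2 to compound 4 (0.09 log units; that floor lies within the scatter), which is expected to be no more than a modest move.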

Compound 4, half-maximal inhibitory concentration: > 100000 nM
Compound 4 ended at the assay's limit; the forecaster's own chance of this, stated with the estimate: 55%; middle value at least 1.2-fold (0.09 log units) from the limit.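

Compound 4, like compound 2, gives only a limit in this assay and no number of its own, so the step from one to the other cannot be read. Both compounds sit at the same limit: the limit of > 100000 nM in this assay, at which 2 of the 4 values shown sit.

The compounds shown leave open how far past that limit each one lies, and therefore whether carboxy in place of iodo changes the number at all.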